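This account rests on a few compounds, and the source may have more. Where it says the series, first, only, none or still open, it means among the compounds named here.

For the measured compounds named here, compound 2, `COc1ccc(C(=O)/C=C/c2cc(-c3cc(OC)c(OC)c(OC)c3)n[nH]2)cc1`, is one of two compounds measured so far in a functional assay on COLO 205 cells (Homo sapiens) for inhibition, read by sulforhodamine B assay, with a stated time of 48 h (a lower number here means a stronger inhibitor of growth, a higher number a weaker inhibitor of growth), where compound 2 gives 1730 nM. Going by the values given here, the only other point is compound 1, `COc1ccc(C(=O)/C=C/c2cc(-c3cc(OC)c(OC)c(OC)c3)n[nH]2)cc1OC`, which in this assay gives 1740 nM; the step of a 1.0-fold lower number from compound 1 to compound 2 (0.00 log units; within the scatter) separates them, so the two stand together rather than apart. The unmeasured compound 3, `COc1cc(-c2cc(/C=C/C(=O)c3ccc(F)c(F)c3)[nH]n2)cc(OC)c1OC`, differs from compound 2 by 3,4-difluorophenyl in place of 4-methoxyphenyl on a carbonyl carbon. Among the compounds with values here, no measured step touches this position on the carbonyl carbon: the single known step concerns a methoxy on the other aromatic ring, and it lies within the scatter. There is therefore no measured basis for expecting a move in this assay beyond the scatter in either direction, and compound 3 is expected to sit near compound 2, with a step of a 1.0-fold lower number from compound 2 to compound 3 (0.01 log units; within the scatter) as the estimate. The estimated value for compound 3 is 1700 nM, with a range from 500 nM to 6000 nM.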

Compound 3, concentration for 50% growth inhibition: 1690 nM
Compound 3: the middle estimate sits 1.0-fold (0.00 log units) above what was measured; measured number inside the range.
By their numbers in this assay, from the lowest: compounds 3, 2 and 1 (each within the scatter of the next).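

The group on the carbonyl carbon now has measured steps: in this assay, 3,4-difluorophenyl in place of 4-methoxyphenyl gives a 1.0-fold lower number from compound 2 to compound 3 (0.01 log units; within the scatter), and 3,4-difluorophenyl in place of 3,4-dimethoxyphenyl gives a 1.0-fold lower number from compound 1 to compound 3 (0.01 log units; within the scatter), so neither step leaves the scatter. At this position, a phenyl ring carrying two fluorines and phenyl rings carrying methoxy groups are therefore not told apart by this read-out, a result the earlier pair, which differed by a single methoxy, could not give. Nothing in the material shown accounts for why the numbers stay together across this change.

On these data alone, all three compounds carry a substituted phenyl ring on the carbonyl carbon, so it remains open whether a pyridine ring, or a plain methyl in place of the ring, would hold the number. As far as these compounds go, whether an amine or a carboxylic acid on that phenyl ring would do so is also open.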